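Amide nitrogen substituent: the next step in the series

The compounds below may be only part of what the source reports. "The series", "measured", "known", "first", "only" and "open" are said of these compounds alone.

In a physicochemical assay for solubility (on this read-out higher numbers stand for higher solubility and lower numbers for lower solubility), compound 3 `CNC(=O)c1cc(C(=O)NC2CC2)cc2c1OC[C@@]2(C)c1ccccc1` gives >= 138 ug/mL, which is a limit and not a number. Compound 1 `CNC(=O)c1cc(C(=O)N[C@H]2[C@@H]3COC[C@@H]32)cc2c1OC[C@@]2(C)c1ccccc1` gives >= 147 ug/mL, also a limit. Compound 2 `CNC(=O)c1cc(C(=O)N[C@H]2C[C@@H]2C)cc2c1OC[C@@]2(C)c1ccccc1` gives a plain number, 3 ug/mL.

Compound 4 `CNC(=O)c1cc(C(=O)N[C@H]2[C@@H]3C[C@@H](O)C[C@@H]32)cc2c1OC[C@@]2(C)c1ccccc1` differs at one place: a group of 7 heavy atoms (6 carbon, 1 oxygen; one three-membered non-aromatic ring of carbon only, one five-membered non-aromatic ring of carbon only) in place of a group of 3 heavy atoms (3 carbon; one three-membered non-aromatic ring of carbon only), on an amide-type nitrogen. Three measured steps change this same substituent. Two are large: an at least 49-fold lower number from compound 1 to compound 2 (1.69 log units; beyond the scatter) and an at least 46-fold higher number from compound 2 to compound 3 (1.66 log units; beyond the scatter). Both involve compound 2, so they show how far one change here can move the read-out. The third, a step that the two limits leave unreadable from compound 1 to compound 3, gives no size. Compound 1 is the nearest guide, as its group also holds one three-membered ring and one five-membered ring, and its result in this assay is the limit >= 147 ug/mL.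

No step beyond the scatter is expected, and the estimated change is an at least 1.1-fold lower number from compound 3 to compound 4 (0.06 log units; that floor lies within the scatter). The low end stays wide given compound 2 at 3 ug/mL. For compound 4 the estimate is 120 ug/mL, with an expected range of 30 ug/mL to 200 ug/mL.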

Compound 4, solubility: >= 209 ug/mL
Compound 4 ended at the assay's limit; the forecaster's own chance of this, stated with the estimate: 50%; middle value at least 1.7-fold (0.24 log units) away from the limit.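

In this assay compound 4 gives >= 209 ug/mL, which is a limit and not a number. Going by these compounds alone, a group of 7 heavy atoms with a five-membered ring of carbon only thus ends at a limit on this amide-type nitrogen, as do the groups of compound 1 and compound 3, so a reading at a limit does not depend on a hetero atom inside the five-membered ring, and compound 2 is the one compound that goes against this pattern. Within the data shown here, the only plain number in the set stays far away, with an at least 69-fold higher number from compound 2 to compound 4 (1.84 log units; beyond the scatter).

The steps among the three limits cannot be read, so no order can be given for compound 1, compound 3 and compound 4. Also open, on these data alone, is whether an amine or a carboxylic acid on the five-membered ring, or an ethyl on the three-membered ring, would end at a limit or at a plain number like that of compound 2.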